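Amino-oxadiazole analogue of compound 2: expected whole-animal activity

A few compounds are considered here, and "the series" means these few. Any claim that something is new, unique, unknown or untested is made for them only; others in the source may bear on it.

Three compounds of the series share one core and differ at its two ends. Compound 1 `CCSc1nnc(Cc2ccc(Cl)cc2Oc2ccccc2Cl)[nH]1` gives 140% in a functional assay on the whole organism (strain NMRI) with Mus musculus as the target, with a stated time of 60 min, at a dose of 10 mg/kg by the intraperitoneal route; on this read-out higher numbers stand for a stronger effect at the one dose given and lower numbers for a weaker effect. Compound 2 `CCSc1nnc(Cc2ccc(Cl)cc2Oc2ccccc2F)[nH]1` gives 144% in this assay, and compound 3 `CCCSc1nnc(Cc2ccc(Cl)cc2Oc2ccccc2F)[nH]1` gives 127%. Among the compounds with values here, compound 2 stands highest of the three numbers, but the step of a number 4 percentage points higher from compound 1 to compound 2 (within the scatter) is within the scatter, so compounds 1 and 2 are not separated; only the step of a number 17 percentage points lower from compound 2 to compound 3 (beyond the scatter) lies beyond it.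

Compound 4 `Nc1nnc(Cc2ccc(Cl)cc2Oc2ccccc2F)o1` is not yet measured. It differs from compound 2 by a group of 6 heavy atoms (2 carbon, 3 nitrogen, 1 oxygen; one five-membered aromatic ring with 3 hetero atoms) in place of a group of 8 heavy atoms (4 carbon, 3 nitrogen, 1 sulfur; one five-membered aromatic ring with 3 hetero atoms), on a saturated chain carbon bound to an aromatic carbon. Within the data shown here, no measured step touches the five-membered ring itself; the nearest comparison is a number 17 percentage points lower from compound 2 to compound 3 (beyond the scatter), which altered only one saturated chain carbon of the group that leaves and cost a modest amount. The change to compound 4 replaces that whole group rather than one chain carbon, so the measured steps give no firm direction; a loss of the size seen, or somewhat more, is the working assumption, with wide uncertainty either way.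

For compound 4 the expected value in this assay is 110%, within 70% to 150%. The expected step of a number 34 percentage points lower from compound 2 to compound 4 (beyond the scatter) is thus downward and modest.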

Compound 4, a percentage reported as activity, at one dose (the size of the read-out at that dose, not a potency): 129%
Beside the measured number, compound 4's estimate is 19 percentage points below it; the measured number falls inside the stated range.
By their numbers in this assay, from the lowest: compounds 3 and 4 (each within the scatter of the next); then compounds 1 and 2 (each within the scatter of the next).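

The exchange at the saturated chain carbon bound to an aromatic carbon replaces the whole group, yet a number 15 percentage points lower from compound 2 to compound 4 (beyond the scatter) in this assay is a modest step and lies beyond the scatter. Within the data shown here, a change of the entire five-membered ring and its sulfur chain therefore costs a loss printed as modest, the same description as that of the single chain-carbon step a number 17 percentage points lower from compound 2 to compound 3 (beyond the scatter), so the sulfur is not required for a substantial read-out. No measurement here offers a cause for the loss.

From the compounds shown here alone, compound 4 changes the ring and its end group together, so the share of each in the step remains open. A dimethylamino group or a butyl chain at that end of the ring would test how far the end group alone sets the read-out.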